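This account rests on a few compounds, and the source may have more. Where it says the series, first, only, none or still open, it means among the compounds named here.

Measured compounds:
- compound 1 `C=CCn1c(=O)/c(=C\c2cccc(Cl)c2)[nH]c(=O)/c1=C\c1ccccc1OC` — in a functional assay on MCF7 cells (Homo sapiens) for cytotoxicity, read by CCK-8 assay, with a stated time of 72 h (on this read-out higher numbers stand for weaker inhibition and lower numbers for stronger inhibition), compound 1 gives 5200 nM
- compound 2 `C=CCn1c(=O)/c(=C\c2ccccc2Cl)[nH]c(=O)/c1=C\c1ccccc1OC` — in this assay compound 2 gives 4700 nM
- compound 3 `C=CCn1c(=O)/c(=C\c2ccc(Cl)c(Cl)c2)[nH]c(=O)/c1=C\c1ccccc1OC` — in this assay compound 3 gives "not active" (no number reported), with no number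

Compound 3 therefore stands apart on the numbers shown: compound 1 and compound 2 each give a value, while compound 3 gives none. Compound 4 `C=CCn1c(=O)/c(=C\c2ccccc2C(F)(F)F)[nH]c(=O)/c1=C\c1ccccc1OC` differs from compound 3 in one place: 2-(trifluoromethyl)phenyl in place of 3,4-dichlorophenyl on a double-bonded chain carbon bound to an aromatic carbon. For the measured compounds named here, no measured step covers this change. Going by the values given here, the only measured step, a 1.1-fold lower number from compound 1 to compound 2 (0.04 log units; within the scatter), moves a single chlorine around the same ring and lies within the scatter, so it gives no direction for exchanging a 3,4-dichlorophenyl for a 2-(trifluoromethyl)phenyl. Compound 4 shares with compound 2 a single group on its ring, and compound 2 gives 4700 nM, so compound 4 is expected to land in the same region, though with a real chance of coming out without a number, as compound 3 did. Compound 4 is thus estimated at 6000 nM in this assay, with a range from 2000 nM to 25000 nM.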

Compound 4, half-maximal inhibitory concentration: 6500 nM
Compound 4: the middle estimate sits 1.1-fold (0.03 log units) below what was measured, and the stated range covers the measured number.
By their numbers in this assay, from the lowest: compounds 2, 1 and 4 (each within the scatter of the next).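

In this assay, for the compounds shown here, the place on a double-bonded chain carbon bound to an aromatic carbon now carries a 2-(trifluoromethyl)phenyl and still gives a number, so a chlorophenyl is not the only group there that does. Trifluoromethyl in place of chloro on an aromatic carbon shows a 1.4-fold higher number from compound 2 to compound 4 (0.14 log units; within the scatter) and 2-(trifluoromethyl)phenyl in place of 3-chlorophenyl shows a 1.3-fold higher number from compound 1 to compound 4 (0.10 log units; within the scatter) and so neither exchange separates the compounds. Compound 3, with its 3,4-dichlorophenyl, remains the only one of the four without a number.

The compounds shown leave open whether an amine or a carboxylic acid on this ring would still give a number. Nothing available here explains why compound 3 gives no number while compound 4 does.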